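Chlorine for Fluorine: Tolerance Expected to Stay at the Limit

The compounds below may be only part of what the source reports. "The series", "measured", "known", "first", "only" and "open" are said of these compounds alone.

Compound 1 `Cc1nc(C(NC(=O)C(=O)Nc2ccc(F)cc2F)C2CCCCN2)sc1CCO`: > 84000 nM
Compound 2 `Cc1nc(C(NC(=O)C(=O)Nc2ccc(F)c(F)c2)C2CCCCN2)sc1CCO`: > 78200 nM

In an ADME assay on TZM-b1 cells (Homo sapiens) for cytotoxicity, read by XTT assay, with a stated time of 3 days (a higher number here means that more compound is tolerated, a lower number that less compound is tolerated), compound 1 gives > 84000 nM, which is a limit of the assay and not a number. Compound 2 gives > 78200 nM, again a limit. Within the data shown here, compound 2 therefore stands at a limit only, as does the single other value shown (the limit of > 84000 nM in this assay, at which 1 of the 2 values shown sits). The step that the two limits leave unreadable from compound 1 to compound 2 cannot be read from two limits.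

Compound 3 `Cc1nc(C(NC(=O)C(=O)Nc2ccc(Cl)c(F)c2)C2CCCCN2)sc1CCO` differs from compound 2 by chloro in place of fluoro on an aromatic carbon. Among the measured compounds shown here, no measured step concerns this change, and the one measured step, a step that the two limits leave unreadable from compound 1 to compound 2, has no readable size. Both measured values sit at limits (the limit of > 78200 nM in this assay, at which 1 of the 2 values shown sits, (the limit of > 84000 nM in this assay, at which 1 of the 2 values shown sits)), so compound 3 is expected to stay at the same level, an expected step that the limit leaves unreadable from compound 2 to compound 3. The estimate for compound 3 is 80000 nM, expected to lie between 40000 nM and 160000 nM, most likely reported as a limit again.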

Compound 3, half-maximal cytotoxic concentration: 61000 nM
Estimate against measurement, compound 3: 1.3-fold (0.12 log units) above; low and high end bracket the measured number.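

In this assay compound 3 gives 61000 nM, the only value of the three shown that is a number and not a limit, and the swap of fluoro for chloro gives an at least 1.2-fold lower number from compound 2 to compound 3 (0.10 log units; that floor lies within the scatter), while the wider change of the ring pattern gives an at least 1.3-fold lower number from compound 1 to compound 3 (0.13 log units; that floor lies within the scatter). Both steps are floors that lie within the scatter, so they show no clear loss of tolerance, and they are floors only because compound 2 stands at a limit of the assay: the limit of > 78200 nM in this assay, at which 1 of the 3 values shown sits. The same holds for the second step, because compound 1 also stands at a limit of the assay: the limit of > 84000 nM in this assay, at which 1 of the 3 values shown sits.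

As far as these compounds go, the true size of both steps stays open, and the step between the two difluorophenyl compounds cannot be read. Also open, from the compounds shown here alone, is whether a bromo, a methyl or a methoxy group at this place on the ring would leave tolerance at the level of chloro.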